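Trisubstituted phenylureas with cycloheptyl: aryl tail variations

The compounds below may be only part of what the source reports. "The series", "measured", "known", "first", "only" and "open" are said of these compounds alone.

Measured so far in an assay on microsomes from intestine for inhibition of acyl-CoA:cholesterol acyltransferase (Oryctolagus cuniculus); on this read-out lower numbers stand for stronger inhibition and higher numbers for weaker inhibition:
compound 1 `Cc1cc(C)c(NC(=O)N(Cc2cc(-c3ccccc3)on2)C2CCCCCC2)c(C)c1` gives 61 nM
compound 2 `Cc1cc(C)c(NC(=O)N(Cc2ccc(N3CCN(C)CC3)cc2)C2CCCCCC2)c(C)c1` gives 57 nM
compound 3 `Cc1cc(C)c(NC(=O)N(Cc2cccc(-c3cc[nH]n3)c2)C2CCCCCC2)c(C)c1` gives 65 nM

Compound 2 carries the lowest of the three numbers in this assay, but its gap to compound 1 and to compound 3 lies within the scatter, so the three compounds cannot be told apart on these data. The shared core, with the trimethylphenyl urea and the cycloheptyl group, is unchanged across the set; only the arylmethyl tail is varied, and so far the tail has made no difference that can be read.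

Compound 4 `Cc1cc(C)c(NC(=O)N(Cc2ccc(-c3ccn(C)n3)cc2)C2CCCCCC2)c(C)c1` is not yet measured. It differs from compound 2 by one change: 1-methyl-1H-pyrazol-3-yl in place of 4-methylpiperazin-1-yl on an aromatic carbon, para to a large group. Going by the values given here, no step between measured compounds isolates this change. Since compound 3, which also carries a pyrazolyl on the benzylic ring, gives 65 nM, no step beyond the scatter is expected from compound 2 to compound 4, an expected change of a 1.1-fold higher number from compound 2 to compound 4 (0.06 log units; within the scatter). Compound 4 is therefore estimated at 65 nM, with a range from 30 nM to 140 nM.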

Compound 4, half-maximal inhibitory concentration: 44 nM
Estimate against measurement, compound 4: 1.5-fold (0.17 log units) above, and the stated range covers the measured number.
By their numbers in this assay, from the lowest: compounds 4, 2, 1 and 3 (each within the scatter of the next).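

In this assay, going by these compounds alone, 1-methyl-1H-pyrazol-3-yl in place of 4-methylpiperazin-1-yl on an aromatic carbon, para to a large group, gives a 1.3-fold lower number from compound 2 to compound 4 (0.11 log units; within the scatter), the first comparison that isolates a single change. On this read-out, a five-membered aromatic ring and a six-membered non-aromatic ring cannot be told apart at this position, so the change from one ring type to the other brings no readable gain or loss. Nothing measured here accounts for the two groups reading alike.

Open, from the compounds shown here alone, is whether any group on this aromatic carbon can move the number beyond the scatter, which a carboxylic acid or a primary amine there would test. Also open, going by these compounds, is what the methyl on the pyrazole contributes, which the unmethylated 1H-pyrazol-3-yl on the same carbon would show.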